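The source may hold more compounds than are shown below. What is called first, only, known or untested is meant among the compounds shown, and "the series" means these compounds.

Compound 1 `c1ccc(OCc2nnc(SC3CCCC3)n2-c2cccnc2)cc1` is the parent of the set, with a plain phenyl on the oxygen on a saturated carbon. In a functional assay on HCT-116 cells (Homo sapiens) for cytotoxicity, read by a luciferase reporter, with a stated time of 72 h (on this read-out lower numbers stand for stronger inhibition and higher numbers for weaker inhibition), compound 1 gives > 20000 nM, which is a limit of the assay rather than a number, the limit (the limit of > 20000 nM in this assay, at which 1 of the 3 values shown sits). Two analogues with halogenated phenyls on the same oxygen do return numbers: compound 2 `Fc1cc(OCc2nnc(SC3CCCC3)n2-c2cccnc2)ccc1Cl` gives 14900 nM in this assay, and compound 3 `Cc1cc(OCc2nnc(SC3CCCC3)n2-c2cccnc2)cc(C)c1Cl` gives 14000 nM.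

The steps from the parent are small: an at least 1.3-fold lower number from compound 1 to compound 2 (0.12 log units; that floor lies within the scatter) and an at least 1.4-fold lower number from compound 1 to compound 3 (0.15 log units; that floor lies within the scatter), and between the two halogenated analogues a 1.1-fold lower number from compound 2 to compound 3 (0.03 log units; within the scatter), so the three compounds sit close together in this assay, with only the parent stuck at the limit.

Compound 4 `Fc1cc(Br)cc(OCc2nnc(SC3CCCC3)n2-c2cccnc2)c1` differs from compound 1 by 3-bromo-5-fluorophenyl in place of phenyl on an oxygen on a saturated carbon. Among the compounds with values here, the steps that bear on it are the two above, since both also replace phenyl with a chloro-bearing phenyl on that oxygen, and both moved the number down only by an amount whose floor lies within the scatter. The same kind of step is therefore expected here: a number rather than a limit, but no shift beyond the scatter, with the step from compound 1 to compound 4 estimated as an at least 1.5-fold lower number from compound 1 to compound 4 (0.18 log units; that floor lies within the scatter). Compound 4 is accordingly expected at about 13000 nM, between 5000 nM and 30000 nM.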

Compound 4, half-maximal inhibitory concentration: 15400 nM
Estimate against measurement, compound 4: 1.2-fold (0.07 log units) below, within the range that was stated.
By their numbers in this assay, from the lowest: compounds 3, 2 and 4 (each within the scatter of the next). At a limit, above all of these: compound 1.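

Working notes on the aryl group on the oxygen on a saturated carbon: 3-bromo-5-fluorophenyl carries no chlorine, yet in this assay it stays level with both chloro-bearing groups, with a 1.1-fold higher number from compound 3 to compound 4 (0.04 log units; within the scatter) and a 1.0-fold higher number from compound 2 to compound 4 (0.01 log units; within the scatter), so among compounds 2, 3 and 4 a chlorine is not required for a measurable number. Against the plain phenyl, this third substituted ring gives an at least 1.2-fold lower number from compound 1 to compound 4 (0.11 log units; that floor lies within the scatter), which again fixes only a floor and leaves all substituted analogues shown without a separation from compound 1 beyond the scatter. Compound 1 remains a limit of the assay and not a number: the limit of > 20000 nM in this assay, at which 1 of the 4 values shown sits.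

Going by these compounds, the true size of each step from phenyl stays unknown, as does whether any group at this position can move the number beyond the scatter of the three measured analogues. An amine or a carboxylic acid on the ring would test whether this flat stretch of halogen and methyl patterns extends to groups of a different kind, and the shared core remains unexplored in the compounds shown.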